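The compounds below may be only part of what the source reports. "The series", "measured", "known", "first", "only" and "open" are said of these compounds alone.

Compound 1, `CCCSc1nc(N)c(N(CCC)CCC)c(=O)[nH]1`, and compound 2, `CCCSc1nc(N)c(N(CCC)CCC)c(=O)n1CC`, share a core and differ only in ethyl in place of hydrogen on an aromatic nitrogen. In a functional assay on cardiac atrium (Cavia porcellus) (a higher number here means that more compound is needed for the effect, a lower number that less compound is needed), compound 1 gives 1960 nM, and in this assay compound 2 gives 600 nM; this is a 3.3-fold lower number from compound 1 to compound 2 (0.51 log units; beyond the scatter). Compound 3, `CC(=O)Nc1nc(SCc2ccccc2)[nH]c(=O)c1N(Cc1ccccc1)Cc1ccccc1`, carries a different set of groups on its core, and how its core differs from that of compound 1 is not broken down here. In this assay compound 3 gives 1410 nM, which sits within the scatter of compound 1 and beyond it from compound 2.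

Compound 4, `CCn1c(SCc2ccccc2)nc(NC(C)=O)c(N(Cc2ccccc2)Cc2ccccc2)c1=O`, has not yet been tested. It differs from compound 3 in ethyl in place of hydrogen on an aromatic nitrogen. This is the same kind of change as that from compound 1 to compound 2, though the surroundings differ: here the ring nitrogen is ortho to a benzylsulfanyl group, meta to a large group and para to an acetamido group, whereas in compound 1 it was ortho to a propylsulfanyl group, meta to a dipropylamino group and para to an amino group. On this single precedent, the step from compound 3 to compound 4 is expected to be a 2.8-fold lower number from compound 3 to compound 4 (0.45 log units; beyond the scatter). Compound 4 is therefore estimated at 500 nM in this assay, with a plausible span from 200 nM to 1300 nM.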

Compound 4, half-maximal effective concentration: 290 nM
Compound 4: middle estimate off by 1.7-fold (0.24 log units), on the high side; the measured number falls inside the stated range.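

Placing ethyl on the aromatic nitrogen again lowers the number in this assay, giving a 4.9-fold lower number from compound 3 to compound 4 (0.69 log units; beyond the scatter) on a core with different groups. The change therefore carries over from the core of compound 1 to that of compound 3, and the two steps agree in size as far as these measurements can tell: the same change on two cores in this assay, a 3.3-fold lower number (0.51 log units; beyond the scatter) from compound 1 to compound 2 and a 4.9-fold lower number (0.69 log units; beyond the scatter) from compound 3 to compound 4, 1.5-fold (0.17 log units) apart, within the scatter of two such steps. For the compounds shown here, this rests on only two pairs in one assay, so it does not show that the step would hold on other cores or in other assays, and it does not explain why the number falls.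

Going by these compounds, only hydrogen and ethyl appear on this nitrogen, so it remains open whether methyl, a longer chain such as butyl, or a benzyl group there would move the number in the same direction or by a similar amount. Also open is whether the step would survive on a core carrying a carboxylic acid or a morpholine in place of the groups shown.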